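From 4-chlorophenyl to 2,4-difluorophenyl: working notes

The source may hold more compounds than are shown below. What is called first, only, known or untested is meant among the compounds shown, and "the series" means these compounds.

In a functional assay on PC-3 cells (Homo sapiens) (a higher number here means a weaker inhibitor of growth, a lower number a stronger inhibitor of growth), compound 1 (`O=S(=O)(/C=C/c1ccc(Cl)c(Cl)c1)Cc1ccc(Nc2ncnc3ccccc23)cc1`) gives 35000 nM and compound 2 (`O=S(=O)(/C=C/c1ccc(Cl)cc1)Cc1ccc(Nc2ncnc3ccccc23)cc1`) gives 43000 nM. Among the compounds with values here, these two numbers lie within the scatter of each other, so compound 2 stands level with the only other measured compound.

Compound 3 (`O=S(=O)(/C=C/c1ccc(F)cc1F)Cc1ccc(Nc2ncnc3ccccc23)cc1`) has yet to be measured in this assay. Its difference from compound 2 is 2,4-difluorophenyl in place of 4-chlorophenyl on a double-bonded chain carbon bound to a double-bonded chain carbon. In short, 2,4-difluorophenyl replaces 4-chlorophenyl on a double-bonded chain carbon bound to a double-bonded chain carbon.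

Within the data shown here, only one measured step bears on this change: a 1.2-fold higher number from compound 1 to compound 2 (0.09 log units; within the scatter). It exchanges chloro for hydrogen on an aromatic carbon and stays within the scatter. Among the measured compounds shown here, no measured compound carries fluorine, so the evidence for compound 3 is indirect, and the range has to stay wide. For the measured compounds named here, with only that small step as a guide, no shift beyond the scatter is expected. The expected step is a 1.1-fold lower number from compound 2 to compound 3 (0.03 log units; within the scatter). For compound 3 the estimated value is 40000 nM, with an expected range of 17000 nM to 90000 nM.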

Compound 3, concentration for 50% growth inhibition: > 100000 nM
Compound 3 ended at the assay's limit; the forecaster's own chance of this, stated with the estimate: 10%; at least 2.5-fold (0.39 log units) between middle value and limit.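

In this assay compound 3 gives > 100000 nM, a limit of the assay and not a number, and it is the only compound shown that sits there: the limit of > 100000 nM in this assay, at which 1 of the 3 values shown sits. Within the data shown here, this position is not indifferent to the aromatic group it carries: an at least 2.3-fold higher number from compound 2 to compound 3 (0.36 log units; beyond the scatter) and an at least 2.8-fold higher number from compound 1 to compound 3 (0.45 log units; beyond the scatter) both lie beyond the scatter, whereas the one earlier step, a 1.2-fold higher number from compound 1 to compound 2 (0.09 log units; within the scatter), stayed within it. On a double-bonded chain carbon bound to a double-bonded chain carbon, 2,4-difluorophenyl therefore goes with a weaker inhibitor of growth than either 4-chlorophenyl or 3,4-dichlorophenyl, and both new steps give only a lower bound on the true size of the change.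

From the compounds shown here alone, the change swaps the halogen and its ring pattern together, so it stays open whether the loss follows fluorine or the pattern, a question that a 4-fluorophenyl or a 2,4-dichlorophenyl analogue would separate. Going by these compounds, how a ring bearing an amine or a carboxylic acid would read at this place in this assay also remains open.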